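This account rests on a few compounds, and the source may have more. Where it says the series, first, only, none or still open, it means among the compounds named here.

Measured compounds:
Compound 1 `C#CCNC(=O)c1ccc(C(CC)(CC)c2ccc(OCC(=O)C(C)(C)C)c(C)c2)n1CC` gives 2200 nM in an assay on HL-60 cells for agonist activity at vitamin D3 receptor (Homo sapiens), read by microscopy, with a stated time of 96 h; on this read-out lower numbers stand for an effect already at smaller amounts and higher numbers for an effect only at larger amounts of compound.
Compound 2 `C#CCNC(=O)c1ccc(C(CC)(CC)c2ccc(OCC(O)C(C)(C)C)c(C)c2)n1CC` gives 240 nM in this assay.
Compound 3 `C#CC(C)OC(=O)c1ccc(C(CC)(CC)c2ccc(OCC(O)C(C)(C)C)c(C)c2)n1CC` gives 200 nM in this assay.

Compound 1 stands highest of the three numbers in this assay; the nearest is compound 2, reached by a 9.2-fold lower number from compound 1 to compound 2 (0.96 log units; beyond the scatter), and the furthest is compound 3. The unmeasured compound 4 `CCn1c(C(=O)N(C)CC(=O)O)ccc1C(CC)(CC)c1ccc(OCC(=O)C(C)(C)C)c(C)c1` keeps the (tert-butyl)carbonyl chain of compound 1 and differs only at the carbonyl carbon: (carboxymethyl)(methyl)amino in place of propargylamino on a carbonyl carbon. Within the data shown here, the one measured step at that carbonyl carbon, a 1.2-fold lower number from compound 2 to compound 3 (0.08 log units; within the scatter), was within the scatter, which suggests that this position has tolerated one exchange without a clear shift. Among the measured compounds shown here, that exchange kept the triple bond, whereas the group entering in compound 4 brings in a carboxylic acid; no measured pair speaks to such a group. The expectation for compound 4 is therefore a small step toward higher numbers in this assay, or none beyond the scatter, with a wide range. Compound 4 is estimated at 4500 nM, between 1200 nM and 18000 nM, which means an expected step of a 2.0-fold higher number from compound 1 to compound 4 (0.31 log units; beyond the scatter).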

Compound 4, half-maximal effective concentration: 1390 nM
For compound 4 the middle estimate is 3.2-fold (0.51 log units) above the measured one; the range from low to high includes it.
By their numbers in this assay, from the lowest: compounds 3 and 2 (each within the scatter of the next); then compounds 4 and 1 (each within the scatter of the next).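

In this assay, putting (carboxymethyl)(methyl)amino in place of propargylamino on a carbonyl carbon gives a 1.6-fold lower number from compound 1 to compound 4 (0.20 log units; within the scatter) on the (tert-butyl)carbonyl chain. The position has thus absorbed a second exchange without a shift beyond the scatter, this time one that removes the triple bond and brings in a carboxylic acid, and on a different chain from the exchange between compound 2 and compound 3, which was read on the 1-hydroxy-2,2-dimethylpropyl chain. Nothing available offers an explanation for this tolerance.

On these data alone, whether (carboxymethyl)(methyl)amino would also leave the number unchanged on the 1-hydroxy-2,2-dimethylpropyl chain of compound 2 stays open. So does the outcome at this carbonyl carbon for a longer chain carrying the carboxylic acid, for its methyl ester, or for a primary amine.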